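A few compounds are considered here, and "the series" means these few. Any claim that something is new, unique, unknown or untested is made for them only; others in the source may bear on it.

Compound 1 `NC(=O)CNCc1ccccc1` gives 490 mg/kg
Compound 2 `C[C@@H](NCc1ccc(OCc2ccccc2Cl)cc1)C(N)=O` gives 17.4 mg/kg
Compound 3 `CNC(=O)[C@@H](CO)NCc1ccc(OCc2ccccc2C(F)(F)F)cc1` gives 85.6 mg/kg

These three compounds were tested in a functional assay on the whole organism with Mus musculus as the target; on this read-out higher numbers stand for an effect only at larger amounts of compound and lower numbers for an effect already at smaller amounts. Compound 2 has the lowest number of the three, and the gaps to compound 3 and to compound 1 both lie beyond the scatter. Compound 4 `C[C@@H](NCc1ccc(OCC2CCCCC2)cc1)C(N)=O` differs from compound 2 in one place, with cyclohexyl in place of 2-chlorophenyl on a saturated chain carbon bound to an oxygen on an aromatic ring. Going by the values given here, no pair of measured compounds shows this change on its own, so the data offer no direct precedent for it. Among the compounds with values here, with compound 2 at the low end of the numbers so far, a modest move towards larger doses seems more likely than a further drop, and it would probably lie only a little beyond the scatter. The expected change is a 2.3-fold higher number from compound 2 to compound 4 (0.36 log units; beyond the scatter) in this estimate. For compound 4 the estimated value in this assay is 40 mg/kg, with an expected range from 15 mg/kg to 105 mg/kg.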

Compound 4, dose for half-maximal effect: 131 mg/kg
For compound 4 the middle estimate is 3.3-fold (0.52 log units) below the measured one; the whole stated range lies below it.
By their numbers in this assay, from the lowest: compound 2; then compounds 3 and 4 (each within the scatter of the next); then compound 1.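

In this assay the exchange of 2-chlorophenyl for cyclohexyl on a saturated chain carbon bound to an oxygen on an aromatic ring gives a 7.5-fold higher number from compound 2 to compound 4 (0.88 log units; beyond the scatter) and so shows that this place responds to the group it carries. The earlier compounds shown here differed from one another in more than one place and could not isolate any single group, whereas this pair ties the difference to this one exchange. Nothing at hand accounts for the size of the step, which stands as an observation only.

The exchange removes the chlorine and the aromatic ring together, so the compounds shown do not tell which of the two changes matters. Going by these compounds, a plain phenyl at this place would separate them, and how a longer chain or an amine would read there also remains open.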